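Replacing 3-methylpiperazin-1-yl with morpholin-4-yl on a carbonyl

This account rests on a few compounds, and the source may have more. Where it says the series, first, only, none or still open, it means among the compounds named here.

Measured in a functional assay on A549 cells (Homo sapiens) for inhibition, read by sulforhodamine B assay, with a stated time of 72 h; a higher number here means a weaker inhibitor, a lower number a stronger inhibitor:
- compound 1 `CC1CN(C(=O)c2c(N)sc(-c3ccc(Cl)cc3)c2-c2ccc(Cl)cc2)CCN1`: 4930 nM
- compound 2 `CC1CCN(C(=O)c2c(N)sc(-c3ccc(Cl)cc3)c2-c2ccc(Cl)cc2)CC1`: 1750 nM

Of these two, compound 1 carries the higher number and is the weaker inhibitor. The next compound to be tested is compound 3 `Nc1sc(-c2ccc(Cl)cc2)c(-c2ccc(Cl)cc2)c1C(=O)N1CCOCC1`, which keeps the core of compound 1 and has morpholin-4-yl in place of 3-methylpiperazin-1-yl on a carbonyl carbon.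

Going by the values given here, only one measured step bears on this change. It is a 2.8-fold lower number from compound 1 to compound 2 (0.45 log units; beyond the scatter), a modest step that also removes 3-methylpiperazin-1-yl from the same carbonyl carbon, though a different group enters there. Among the compounds with values here, no measured compound yet carries morpholin-4-yl, so this single step offers only weak guidance. On the strength of it, a small move towards a lower number is expected in this assay, perhaps not beyond the scatter, and a move the other way cannot be ruled out. The expected step is a 1.6-fold lower number from compound 1 to compound 3 (0.22 log units; within the scatter). For compound 3 the estimated value is 3000 nM, with an expected range of 1200 nM to 7500 nM.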

Compound 3, half-maximal inhibitory concentration: 1870 nM
Beside the measured number, compound 3's estimate is 1.6-fold (0.21 log units) above it; low and high end bracket the measured number.
By their numbers in this assay, from the lowest: compounds 2 and 3 (each within the scatter of the next); then compound 1.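

In this assay, the change to morpholin-4-yl gives a 2.6-fold lower number from compound 1 to compound 3 (0.42 log units; beyond the scatter), so a second group in place of 3-methylpiperazin-1-yl now moves the number the same way as 4-methylpiperidin-1-yl, something a single earlier step could not show. The two replacements themselves give a 1.1-fold higher number from compound 2 to compound 3 (0.03 log units; within the scatter), which leaves compound 2 and compound 3 indistinguishable in this assay, so at this carbonyl carbon the data so far set 3-methylpiperazin-1-yl apart from both other groups. Nothing available explains why this group stands apart, although morpholin-4-yl has 0 hydrogen-bond donors where 3-methylpiperazin-1-yl has 1, and that difference alone cannot be tied to the result.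

As far as these compounds go, it remains open whether an unsubstituted piperazine, a piperidine without the methyl group, or an open-chain amine such as dimethylamino on the same carbonyl carbon would fall with compound 1 or with compound 2 and compound 3. From the compounds shown here alone, it is also open whether the step to morpholin-4-yl would be of similar size if the groups on the rest of the shared core were different.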